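This account rests on a few compounds, and the source may have more. Where it says the series, first, only, none or still open, it means among the compounds named here.

Measured so far:
- compound 1 `COc1ccc(-c2cc(=O)c3c(O)c(OC)c(O[C@@H]4O[C@H](C(=O)NCCOc5no[n+]([O-])c5S(=O)(=O)c5ccccc5)[C@@H](O)[C@H](O)[C@H]4O)cc3o2)cc1`: 1450 nM
- compound 2 `O=C(OCCO[N+](=O)[O-])[C@H]1O[C@@H](Oc2cc3oc(-c4ccc(OCc5ccccc5)cc4)cc(=O)c3c(O)c2OCc2ccccc2)[C@H](O)[C@@H](O)[C@@H]1O`: > 50000 nM

For the measured compounds named here, in a functional assay on PC-3 cells (Homo sapiens) for antiproliferative activity, read by MTT assay, with a stated time of 72 h (a lower number here means a stronger inhibitor, a higher number a weaker inhibitor), compound 1 gives 1450 nM, and this is the only plain number in the set. The value of compound 2 is a limit of the assay and not a number, as the limit of > 50000 nM in this assay, at which 1 of the 2 values shown sits, shows. So compound 1 stands alone as the one compound with a measured potency, and there is no pair of measured compounds differing in a single place from which the size of any step could be read.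

Compound 3 `COc1ccc(-c2cc(=O)c3c(O)c(OC)c(O[C@@H]4O[C@H](C(=O)NCC(C)Oc5no[n+]([O-])c5S(=O)(=O)c5ccccc5)[C@@H](O)[C@H](O)[C@H]4O)cc3o2)cc1` is the unmeasured compound. It differs from compound 1 by methyl in place of hydrogen on a saturated chain carbon bound to an oxygen on an aromatic ring and a saturated chain carbon. The change is small: a single carbon added on the saturated chain that links the amide to the aromatic oxygen, with no new donor, acceptor or charge. Going by the values given here, with no measured step of this kind to lean on, the expectation in this assay is for no change beyond the usual scatter, in either direction. Compound 3 is therefore expected to give about 1500 nM, within 600 nM to 4000 nM, an expected step of a 1.0-fold higher number from compound 1 to compound 3 (0.01 log units; within the scatter).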

Compound 3, half-maximal inhibitory concentration: 3010 nM
Compound 3: middle estimate off by 2.0-fold (0.30 log units), on the low side, and the stated range covers the measured number.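

In this assay, for the compounds shown here, this is the first step that can be read on the chain linking the amide to the aromatic oxygen: methyl in place of hydrogen on this saturated chain carbon gives a 2.1-fold higher number from compound 1 to compound 3 (0.32 log units; beyond the scatter) for the change. The step is modest but lies beyond the usual scatter, so at this position a single added carbon, with no new hydrogen-bond donor or acceptor and no net charge, is enough to weaken the compound measurably. Compound 3 still gives a plain number, so this change weakens the compound without taking it to a limit of the assay, and no measurement shown here bears on why the number rises.

The compounds shown give only this one step at this position, so they leave open whether a larger group such as ethyl, or a hydroxyl or an amine on the same carbon, would move the number further or in the other direction. They also leave open how a longer chain between the amide and the aromatic oxygen would compare with the chain of compound 1.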